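Swapping the thioether heteroaryl for a benzotriazolyloxy group

The compounds below may be only part of what the source reports. "The series", "measured", "known", "first", "only" and "open" are said of these compounds alone.

Measured compounds:
compound 1 `CC(C)[C@H](NC(=O)COc1cccc2ccccc12)C(=O)N[C@@H](CC(=O)O)C(=O)CSc1nc[nH]n1`: > 200000 nM
compound 2 `Cc1nnc(SCC(=O)[C@H](CC(=O)O)NC(=O)[C@@H](NC(=O)COc2cccc3ccccc23)C(C)C)s1`: 190000 nM

Going by the values given here, in a functional assay on Jurkat cells (Homo sapiens) for inhibition (on this read-out higher numbers stand for weaker inhibition and lower numbers for stronger inhibition), compound 2 gives 190000 nM, the only actual number among the values shown. For compound 1 this assay reports only a limit, > 200000 nM. Among the compounds with values here, the step of an at least 1.0-fold lower number from compound 1 to compound 2 (0.02 log units; that floor lies within the scatter) is therefore the sole measured comparison, and it lies within the scatter; this is consistent with the limit of > 200000 nM in this assay, at which 1 of the 2 values shown sits.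

Compound 3 `CC(C)[C@H](NC(=O)COc1cccc2ccccc12)C(=O)N[C@@H](CC(=O)O)C(=O)COn1nnc2ccccc21` differs from compound 2 by a group of 10 heavy atoms (6 carbon, 3 nitrogen, 1 oxygen; one five-membered aromatic ring with 3 hetero atoms, one six-membered aromatic ring of carbon only) in place of a group of 7 heavy atoms (3 carbon, 2 nitrogen, 2 sulfur; one five-membered aromatic ring with 3 hetero atoms), on a saturated chain carbon bound to a carbonyl carbon. Within the data shown here, no measured step touches this change: the one step known concerns a small heteroaryl swap on a sulfur, not the replacement of the whole sulfanyl heteroaryl by an oxygen-linked bicyclic group. Because compound 2 gives 190000 nM, the starting point for this step sits where inhibition is barely detectable, and no change beyond the scatter can be expected with any confidence. Compound 3 is estimated at 160000 nM in this assay, within 40000 nM to 600000 nM, which means an expected step of a 1.2-fold lower number from compound 2 to compound 3 (0.07 log units; within the scatter).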

Compound 3, half-maximal inhibitory concentration: > 200000 nM
Compound 3 was reported as a limit; the forecaster's own chance of this, stated with the estimate: 50%; at least 1.2-fold (0.09 log units) between middle value and limit.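

In this assay, putting the oxygen-linked bicyclic group in place of (5-methyl-1,3,4-thiadiazol-2-yl)sulfanyl gives an at least 1.0-fold higher number from compound 2 to compound 3 (0.02 log units; that floor lies within the scatter). The earlier step only exchanged one small heteroaryl group on a sulfur, whereas this one replaces the sulfur link as well and adds a second ring, and it still brings no readable gain in inhibition. Two of the compounds now rest on the same limit of the assay, not on a measured number: the limit of > 200000 nM in this assay, at which 2 of the 3 values shown sit.

As far as these compounds go, compound 1 and compound 3 both stand at that limit, so the step between them cannot be read, and how far either lies past it stays unknown. Also open, from the compounds shown here alone, is whether a different oxygen-linked group on this carbon, such as 2,6-difluorophenoxy, would give clear inhibition in this assay.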